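The source may hold more compounds than are shown below. What is called first, only, known or untested is meant among the compounds shown, and "the series" means these compounds.

Compound 1 `COc1cc(/C(Cl)=C/C=C(\C#N)C(=O)c2c[nH]c3ccc(Br)cc23)cc(OC)c1OC` stands lowest of the three numbers in a functional assay for inhibition, read by Griess assay, with a stated time of 150 min, tested at 1 mM (a lower number here means less inhibition, a higher number more inhibition at the concentration tested (going by the name of the read-out)), where compound 1 gives 36.7%. Compound 3 `COc1ccc(/C(Cl)=C/C=C(\C#N)C(=O)c2c[nH]c3ccc(Br)cc23)cc1OC` gives 57.5% in this assay and compound 2 `COc1ccc(/C(Cl)=C/C=C(\C#N)C(=O)c2c[nH]c3ccccc23)cc1` gives 76.9%. Among the compounds with values here, the only step that differs in a single place is a number 20.8 percentage points higher from compound 1 to compound 3 (beyond the scatter), hydrogen in place of methoxy on an aromatic carbon. Compound 4 `COc1cc(/C(Cl)=C/C=C(\C#N)C(=O)c2c(C)[nH]c3ccccc23)cc(OC)c1OC` differs from compound 1 on the carbonyl carbon: 2-methyl-1H-indol-3-yl in place of 5-bromo-1H-indol-3-yl on a carbonyl carbon. Within the data shown here, no measured step touches this part of the shared core, so the step from compound 1 to compound 3 shows only that one change elsewhere moved this assay modestly; compound 2, without bromine, differs in two places and offers no single-step comparison. Compound 4 is therefore expected to shift by a number 13.3 percentage points higher from compound 1 to compound 4 (beyond the scatter), estimated at 50% with a range of 25% to 75%.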

Compound 4, a percentage reported as inhibition, at one concentration (the size of the read-out at that concentration, not a potency): 74.2%
Beside the measured number, compound 4's estimate is 24.2 percentage points below it, and the stated range covers the measured number.
By their numbers in this assay, from the lowest: compound 1; then compound 3; then compounds 4 and 2 (each within the scatter of the next).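

Moving from 5-bromo-1H-indol-3-yl to 2-methyl-1H-indol-3-yl on the carbonyl carbon gives, in this assay, a number 37.5 percentage points higher from compound 1 to compound 4 (beyond the scatter) with the rest of compound 1 unchanged, so this position clearly affects the read-out. The step removes bromine and adds methyl together, so it cannot assign the gain to either alone. Nothing available explains the shift.

Still open, as far as these compounds go, is how an unsubstituted 1H-indol-3-yl or a 5-bromo-2-methyl-1H-indol-3-yl would read here. An ethyl or longer chain in place of the methyl also remains untested among the compounds shown.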